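Adding a Methyl to the Pyrazole of Compound 3

The source may report more compounds than this note shows. Statements on the series, on what has been measured and on what is new or still open speak of the compounds shown alone.

Of the compounds shown here, three sharing one core have been measured in an assay on HeLa cells for binding affinity to Vasopressin V2 receptor (Homo sapiens); on this read-out lower numbers stand for stronger inhibition and higher numbers for weaker inhibition. Compound 1 `CCCNc1ccc(C(=O)N2CCCCc3ccccc32)c(Cl)c1` gives 18 nM. Compound 2 `O=C(c1ccc(N2CCCC2)cc1Cl)N1CCCCc2ccccc21` gives 9 nM, and compound 3 `O=C(c1ccc(-n2cccn2)cc1Cl)N1CCCCc2ccccc21` gives 8.8 nM. Compound 3 thus shows the lowest number of the three, though the step of a 1.0-fold lower number from compound 2 to compound 3 (0.01 log units; within the scatter) lies within the scatter, while the step of a 2.0-fold lower number from compound 1 to compound 3 (0.31 log units; beyond the scatter) is a modest one beyond it; the step of a 2.0-fold lower number from compound 1 to compound 2 (0.30 log units; within the scatter) falls within the scatter.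

Compound 4 `Cc1ccn(-c2ccc(C(=O)N3CCCCc4ccccc43)c(Cl)c2)n1` differs from compound 3 by methyl in place of hydrogen on an aromatic carbon. Within the data shown here, none of the measured steps concerns a methyl added to this ring; all three exchange the whole group attached to the shared core, and the two exchanges that lead to compound 2 and compound 3 end within the scatter of each other. Among the measured compounds shown here, with no step to lean on, such a small change is expected to leave this assay roughly where compound 3 stands. The step of a 1.1-fold lower number from compound 3 to compound 4 (0.04 log units; within the scatter) is therefore expected to fall within the scatter. Compound 4 is estimated at 8 nM, with a range from 3 nM to 25 nM.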

Compound 4, half-maximal inhibitory concentration: 13 nM
The estimate for compound 4 lay 1.6-fold (0.21 log units) below the measured number, within the range that was stated.
By their numbers in this assay, from the lowest: compounds 3, 2, 4 and 1 (each within the scatter of the next, the first and the last beyond it).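

Among these compounds, the earlier compounds exchanged the whole group on the shared core, while this change is the first to touch the pyrazole ring itself. In this assay, methyl in place of hydrogen on an aromatic carbon next to the ring nitrogen gives a 1.5-fold higher number from compound 3 to compound 4 (0.17 log units; within the scatter) and so leaves the number within the scatter, which shows that this position accepts a methyl without a clear shift. Both a 1.4-fold higher number from compound 2 to compound 4 (0.16 log units; within the scatter) and a 1.4-fold lower number from compound 1 to compound 4 (0.14 log units; within the scatter) also stay within the scatter, so 3-methyl-1H-pyrazol-1-yl cannot be told apart from propylamino or pyrrolidin-1-yl here.

The compounds shown leave open what an ethyl group, a longer chain or an amine at this position would do, and what a methyl on the other ring carbons would do. No measurement at hand offers a reason for these numbers.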